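The source may hold more compounds than are shown below. What is called first, only, known or untested is meant among the compounds shown, and "the series" means these compounds.

Compound 1 `CCCn1ccc2cc(/C(C)=C/C(=O)Nc3ccccc3OCCCC(=O)O)ccc21` is the weakest-looking of three close relatives on the numbers shown: in an assay on Prostate gland for inhibition of steroid 5-alpha-reductase (Rattus norvegicus) (on this read-out lower numbers stand for stronger inhibition and higher numbers for weaker inhibition), compound 1 gives 190 nM, the highest of the three values. Compound 2 `CCCCCn1ccc2cc(/C(C)=C/C(=O)Nc3ccccc3OCCCC(=O)O)ccc21` gives 23 nM in this assay, and compound 3 `CC(C)=CCn1ccc2cc(/C(C)=C/C(=O)Nc3ccccc3OCCCC(=O)O)ccc21` gives 120 nM. The two steps that leave compound 1 differ in size: lengthening the chain on the aromatic nitrogen brought an 8.3-fold lower number from compound 1 to compound 2 (0.92 log units; beyond the scatter), whereas swapping in the branched unsaturated group gave only a 1.6-fold lower number from compound 1 to compound 3 (0.20 log units; within the scatter). Between those two, a 5.2-fold higher number from compound 2 to compound 3 (0.72 log units; beyond the scatter).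

Compound 4 `CCCC(CC)n1ccc2cc(/C(C)=C/C(=O)Nc3ccccc3OCCCC(=O)O)ccc21` is compound 1 with a new branch on the chain: propyl in place of hydrogen on a saturated chain carbon bound to an aromatic nitrogen and a saturated chain carbon. For the measured compounds named here, the step that bears most directly on it is the one from compound 1 to compound 2, where added carbon on the same chain lowered the number in this assay beyond the scatter, a modest gain. The change to compound 4 also adds carbon, though as a branch close to the nitrogen rather than at the chain end, and the flat result for compound 3 warns that not every added bulk here helps. He therefore expects a lowering smaller than that seen for compound 2, a 3.2-fold lower number from compound 1 to compound 4 (0.50 log units; beyond the scatter), placing compound 4 at an estimated 60 nM with a likely range from 20 nM to 180 nM.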

Compound 4, half-maximal inhibitory concentration: 9.3 nM
For compound 4 the middle estimate is 6.5-fold (0.81 log units) above the measured one; the whole stated range lies above it.
By their numbers in this assay, from the lowest: compound 4; then compound 2; then compounds 3 and 1 (each within the scatter of the next).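

In this assay the propyl on the saturated chain carbon bound to an aromatic nitrogen and a saturated chain carbon gave a 20-fold lower number from compound 1 to compound 4 (1.31 log units; beyond the scatter) and is the largest step yet seen at this position, which makes compound 4 the strongest of the four, since its steps to all the others lie beyond the scatter. The arrangement of the chain mattered as well as its extension: 1-ethylbutyl in place of pentyl gave a 2.5-fold lower number from compound 2 to compound 4 (0.39 log units; beyond the scatter) as a modest step, while 1-ethylbutyl in place of 3-methylbut-2-en-1-yl gave a 13-fold lower number from compound 3 to compound 4 (1.11 log units; beyond the scatter) as a large one, so the flat result for compound 3 does not extend to every branched group on this nitrogen. Nothing available here accounts for these differences between the groups.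

The compounds shown leave open whether a still longer branched chain such as 1-propylbutyl, or a ring such as cyclohexyl, on the aromatic nitrogen would lower the number further. They also leave open whether 1-ethylbutyl would keep this gain if the carboxylic acid at the end of the other chain gave way to an amide or a tetrazole.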